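This account rests on a few compounds, and the source may have more. Where it says the series, first, only, none or still open, it means among the compounds named here.

Measured so far in a functional assay on Bel-7402 cells (Homo sapiens) for antiproliferative activity, read by MTT assay, with a stated time of 72 h; on this read-out higher numbers stand for weaker inhibition and lower numbers for stronger inhibition:
compound 1 `COc1cccc(CNCc2c(C(=O)O)n(Cc3ccccc3)c3cc(C(C)C)ccc23)c1`: 5900 nM
compound 2 `CCNC(=O)c1c(CNCc2ccc(OC)cc2)c2ccccc2n1Cc1ccc(OC)cc1`: 58900 nM
compound 3 `COc1ccc(Cn2c(C(=O)O)c(CNCc3cccc(O)c3)c3ccccc32)cc1`: a limit, > 50000 nM

Compound 1 gives the lowest of the two numbers here; compound 2 gives a clearly higher number, a gap beyond the usual scatter. For compound 3 only a limit was recorded, not a number: the limit of > 50000 nM in this assay, at which 1 of the 3 values shown sits. Compound 4 `COc1cccc(CNCc2c(C(=O)O)n(Cc3ccccc3)c3ccccc23)c1` has not yet been tested. It differs from compound 1 by hydrogen in place of isopropyl on an aromatic carbon. Among the compounds with values here, no measured pair shows this change on its own, and compound 2 and compound 3, which also lack the isopropyl, differ from compound 1 in other places too. A moderate rise in the number, beyond the scatter, seems the likeliest outcome. Compound 4 is therefore expected at about 18000 nM, between 6000 nM and 55000 nM, which would mean a step of a 3.1-fold higher number from compound 1 to compound 4 (0.48 log units; beyond the scatter).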

Compound 4, half-maximal inhibitory concentration: > 50000 nM
Compound 4 ended at the assay's limit (the forecaster's own chance of this, stated with the estimate: 25%); at least 2.7-fold (0.44 log units) between middle value and limit.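

Swapping isopropyl for hydrogen at this aromatic carbon, seen here on its own for the first time, gives an at least 8.4-fold higher number from compound 1 to compound 4 (0.92 log units; beyond the scatter) in this assay. The value of compound 4, > 50000 nM, is a limit and not a number. Only a minimum for the step can therefore be read, and this limit recurs in the set: the limit of > 50000 nM in this assay, at which 2 of the 4 values shown sit.

Still open, going by these compounds, is whether isopropyl itself matters or whether a smaller methyl, a larger tert-butyl or a chlorine atom at this carbon would serve as well. Also open, on these data alone, is how isopropyl would fare on another carbon of that ring.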